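Two ring stereocentres inverted: compound 2 to compound 4

The source may report more compounds than this note shows. Statements on the series, on what has been measured and on what is new or still open speak of the compounds shown alone.

Of the compounds shown here, three have been measured in a physicochemical assay for solubility, in phosphate buffer; a lower number here means a less soluble compound, a higher number a more soluble compound. Compound 1 `C[C@H]1CN([C@@H](C)CO)C(=O)c2cccc(NC(=O)c3ccncc3)c2O[C@@H]1CN(C)Cc1ccc(Cl)c(Cl)c1` gives 64000 nM, compound 2 `C[C@H](CO)N1C[C@H](C)[C@H](CN(C)Cc2ccc(Oc3ccccc3)cc2)Oc2c(NC(=O)c3ccncc3)cccc2C1=O` gives 98000 nM and compound 3 `C[C@H]1CN([C@@H](C)CO)C(=O)c2cccc(NC(=O)c3ccncc3)c2O[C@H]1CN(C)Cc1ccc(Oc2ccccc2)cc1` gives 93000 nM. Compound 2 therefore stands level with the other two, since its value lies within the scatter of both.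

The open question is compound 4 `C[C@@H]1CN([C@H](C)CO)C(=O)c2cccc(NC(=O)c3ccncc3)c2O[C@@H]1CN(C)Cc1ccc(Oc2ccccc2)cc1`, which is related to compound 2 by a purely stereochemical change: the two compounds have the same atoms and bonds and differ only in configuration as drawn: 2 of 3 stereo elements differ; a stereocentre at a saturated ring carbon is drawn S in compound 2 and R in compound 4; a stereocentre at a saturated ring carbon is drawn R in compound 2 and S in compound 4. Nothing leaves the structure and nothing enters it.

Going by the values given here, one measured step bears on this change, a 1.1-fold lower number from compound 2 to compound 3 (0.02 log units; within the scatter). It is relevant because of the fact that compounds 2 and 3 differ only in the configuration as drawn, although the stereocentre that changes there sits at a saturated chain carbon, not at a saturated ring carbon. The two ring stereocentres have therefore not been tested on their own, and this single small step is a limited guide.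

With no measured step beyond the scatter, no shift in either direction is expected. The expected change is a 1.1-fold lower number from compound 2 to compound 4 (0.04 log units; within the scatter), which would stay within the scatter. The estimated value for compound 4 is 90000 nM, with an expected range of 55000 nM to 135000 nM.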

Compound 4, solubility: 86000 nM
Compound 4: the middle estimate sits 1.0-fold (0.02 log units) above what was measured; low and high end bracket the measured number.
By their numbers in this assay, from the lowest: compounds 1, 4, 3 and 2 (each within the scatter of the next).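

In this assay, going by these compounds alone, the step of a 1.1-fold lower number from compound 2 to compound 4 (0.06 log units; within the scatter) is the first reading on the two saturated ring stereocentres, as the earlier step between compounds had touched only the saturated chain carbon. Inverting that chain carbon as well gives the mirror-image pair, and a 1.1-fold lower number from compound 3 to compound 4 (0.03 log units; within the scatter) shows that even with all stereocentres inverted the number stays within the scatter. Among compound 2, compound 3 and compound 4, each listed step therefore reflects configuration alone, and none of them leaves the scatter: the fact that compounds 2 and 4 differ only in the configuration as drawn

As far as these compounds go, the two ring stereocentres change together in these compounds, so what each contributes alone remains open, as does whether the other configurations of this structure would behave in the same way. From the compounds shown here alone, it is also open whether configuration would stay as silent in this assay if the chain bearing the hydroxyl group ended instead in a carboxylic acid or an amine.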